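The compounds below may be only part of what the source reports. "The series", "measured", "known", "first", "only" and "open" are said of these compounds alone.

Compound 2 `COc1ccc(S(=O)(=O)N2CCC[C@@H]2C(=O)N2CCN(c3ccnc4cc(Cl)ccc34)CC2)cc1` belongs to a set of three compounds built on a shared core, the other two being compound 1 `O=C([C@H]1CCCN1S(=O)(=O)c1ccccc1[N+](=O)[O-])N1CCN(c2ccnc3cc(Cl)ccc23)CC1` and compound 3 `O=C([C@H]1CCCN1S(=O)(=O)c1cc(Cl)ccc1Cl)N1CCN(c2ccnc3cc(Cl)ccc23)CC1`. In an ADME assay on HEK293 cells (Homo sapiens) for cytotoxicity, read by MTT assay, with a stated time of 48 h (on this read-out lower numbers stand for stronger inhibition and higher numbers for weaker inhibition), compound 2 gives 57700 nM, level with compound 1, which gives 57700 nM, the two together the highest of the three numbers; compound 3 gives 38000 nM. Compound 4 `Cc1cc(C)c(S(=O)(=O)N2CCC[C@@H]2C(=O)N2CCN(c3ccnc4cc(Cl)ccc34)CC2)c(C)c1` differs from compound 2 by 2,4,6-trimethylphenyl in place of 4-methoxyphenyl on a sulfonyl sulfur. The measured steps that bear on this are all exchanges of the group on the sulfonyl sulfur: no change at the digits printed from compound 1 to compound 2 (within the scatter), a 1.5-fold lower number from compound 1 to compound 3 (0.18 log units; within the scatter) and a 1.5-fold lower number from compound 2 to compound 3 (0.18 log units; within the scatter), none of them beyond the scatter. Compound 4 is therefore expected to give a number within the usual scatter of what came before, a 1.2-fold lower number from compound 2 to compound 4 (0.06 log units; within the scatter), with an estimated value of 50000 nM and a range from 25000 nM to 100000 nM.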

Compound 4, half-maximal inhibitory concentration: 14700 nM
Compound 4: the middle estimate sits 3.4-fold (0.53 log units) above what was measured; measured number outside the range, below it.
By their numbers in this assay, from the lowest: compound 4; then compounds 3, 1 and 2 (each within the scatter of the next).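

In this assay the group on the sulfonyl sulfur, so far without any step beyond the scatter, now shows a 3.9-fold lower number from compound 2 to compound 4 (0.59 log units; beyond the scatter) and a 3.9-fold lower number from compound 1 to compound 4 (0.59 log units; beyond the scatter) and a 2.6-fold lower number from compound 3 to compound 4 (0.41 log units; beyond the scatter) on changing to 2,4,6-trimethylphenyl. This position can therefore move the number, and compound 4 stands lowest of the four, with all its steps printed as beyond the scatter. Nothing shown here accounts for this change. As far as these compounds go, it remains open whether 4-methylphenyl or plain phenyl would read like 2,4,6-trimethylphenyl, and how an aryl group carrying an amine or a carboxylic acid would read.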